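The source may hold more compounds than are shown below. What is called first, only, known or untested is meant among the compounds shown, and "the series" means these compounds.

Measured in a functional assay on CCRF-CEM cells (Homo sapiens) for cytotoxicity, read by sulforhodamine B assay, with a stated time of 48 h, tested at 0.1 uM; a lower number here means a stronger effect, a higher number a weaker effect of the compound at the concentration tested:
compound 1 `COc1cc(-c2cc(/C=C/C(=O)c3ccc(N)cc3)[nH]n2)cc(OC)c1OC` gives 91%
compound 2 `COc1cc(-c2cc(/C=C/C(=O)c3ccc(Cl)c(Cl)c3)[nH]n2)cc(OC)c1OC` gives 98%
compound 3 `COc1ccc(C(=O)/C=C/c2cc(-c3cc(OC)c(OC)c(OC)c3)n[nH]2)cc1OC` gives 94%

Among these three numbers compound 3 stands second highest; its nearest neighbour is compound 1, and the step of a number 3 percentage points higher from compound 1 to compound 3 (within the scatter) lies within the scatter. Its furthest neighbour is compound 2, and the step of a number 4 percentage points lower from compound 2 to compound 3 (within the scatter) also lies within the scatter, as does the step of a number 7 percentage points higher from compound 1 to compound 2 (within the scatter) between the other two. Every measured change so far has been an exchange of the aryl group on the carbonyl carbon, and none of them moved this assay beyond its scatter.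

Compound 4 `COc1ccc(C(=O)/C=C/c2cc(-c3cc(OC)c(OC)c(OC)c3)n[nH]2)cc1` is the next compound. Compared with compound 3 it differs thus: hydrogen in place of methoxy on an aromatic carbon

This change again sits on the aryl group on the carbonyl carbon, the same place where the three measured steps were all within the scatter. No step beyond the scatter is therefore expected for compound 4; the expected step is a number 1 percentage points lower from compound 3 to compound 4 (within the scatter). For compound 4 the estimated value in this assay is 93%, with a range from 82% to 104%.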

Compound 4, a percentage reported as activity, at one concentration (the size of the read-out at that concentration, not a potency): 98%
For compound 4 the middle estimate is 5 percentage points below the measured one; the range from low to high includes it.
By their numbers in this assay, from the lowest: compounds 1, 3, 2 and 4 (each within the scatter of the next).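

In this assay, hydrogen in place of methoxy on an aromatic carbon turns 3,4-dimethoxyphenyl into 4-methoxyphenyl and gives a number 4 percentage points higher from compound 3 to compound 4 (within the scatter). This is the first change shown that touches one substituent of the aryl group on the carbonyl carbon rather than exchanging the whole group, and it leaves the result within the scatter just as the whole-group exchanges did. The 4-methoxyphenyl group also gives no change at the digits printed from compound 2 to compound 4 (within the scatter) against 3,4-dichlorophenyl, and methoxy in place of amino on an aromatic carbon gives a number 7 percentage points higher from compound 1 to compound 4 (within the scatter), so none of the four aryl groups can be told apart in this assay.

From the compounds shown here alone, what a hydroxy group, a carboxylic acid or a longer alkoxy chain at this position would give in this assay stays open. Nothing shown bears on why these aryl exchanges leave the read-out within the scatter.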